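This account rests on a few compounds, and the source may have more. Where it says the series, first, only, none or still open, it means among the compounds named here.

Two compounds sharing one core have so far gone through a physicochemical assay for lipophilicity, at pH 7.4; on this read-out lower numbers stand for lower lipophilicity and higher numbers for higher lipophilicity. For compound 1, `CC(C)N1C[C@H](C(=O)Nc2ccc(Cl)cc2)[C@@H](C(=O)Nc2ccc(-n3ccccc3=O)cc2F)C1`, the entry reads "not determined" (no result reported), so it offers no comparison. Among the measured compounds shown here, compound 2, `NS(=O)(=O)N1C[C@H](C(=O)Nc2ccc(Cl)cc2)[C@@H](C(=O)Nc2ccc(-n3ccccc3=O)cc2F)C1`, gives 1.83, the only number available, and it therefore has no rank among other values. Compound 3, `CCCOC(=O)N1C[C@H](C(=O)Nc2ccc(Cl)cc2)[C@@H](C(=O)Nc2ccc(-n3ccccc3=O)cc2F)C1`, is still to be measured. It has propoxycarbonyl in place of sulfamoyl on an amine nitrogen in a ring. For the measured compounds named here, no step between measured compounds exists to calibrate this change, so the expectation rests on the structural change alone, starting from compound 2 at 1.83. The expected change is a rise of a number 1.37 log units higher from compound 2 to compound 3 (beyond the scatter), larger than the usual scatter. For compound 3 the estimated value is 3.2, with an expected range from 2.7 to 3.7.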

Compound 3, distribution coefficient: 3.06
Compound 3: middle estimate off by 0.14 log units, on the high side; measured number inside the range.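

In this assay, among the compounds shown here, propoxycarbonyl in place of sulfamoyl on the amine nitrogen in the ring gives a number 1.23 log units higher from compound 2 to compound 3 (beyond the scatter), the only step available at this position. It shows that, with the rest of the structure unchanged, the group on this nitrogen can move the read-out by a large amount. Sulfamoyl carries 1 hydrogen-bond donor and 4 heavy atoms, propoxycarbonyl 0 donors and 6 heavy atoms, but these differences arrive together in one step, and no measurement at hand bears on what accounts for the rise.

From the compounds shown here alone, how much of the step belongs to the propyl chain and how much to the carbonyl remains open. A methoxycarbonyl group, or a propylsulfonyl group on the same nitrogen, would begin to separate the two.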